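This account rests on a few compounds, and the source may have more. Where it says the series, first, only, none or still open, it means among the compounds named here.

In a functional assay on L1210 cells (Mus musculus) for inhibition (on this read-out higher numbers stand for weaker inhibition and lower numbers for stronger inhibition), compound 1 `Nc1nc(O)c2ncn(C/C=C/CO)c2n1` gives 200000 nM as its read-out, compound 3 `Nc1ccn(C=C=CCO)c(=O)n1` gives 560000 nM and compound 2 `Nc1ncnc2c1ncn2C/C=C\CCl` gives 22000 nM as the lowest number of the three, beyond the scatter from both others. Compound 4 `Nc1ncnc2c1ncn2CC#CCCl` departs from compound 2 in one place, with 3-chloroprop-1-yn-1-yl in place of 3-chloroprop-1-en-1-yl on a saturated chain carbon bound to an aromatic nitrogen as the counted difference: 3-chloroprop-1-yn-1-yl in place of 3-chloroprop-1-en-1-yl on a saturated chain carbon bound to an aromatic nitrogen. Among the measured compounds shown here, no measured pair shows this change. Starting from compound 2 at 22000 nM as the only anchor, no shift beyond the scatter is expected in this assay for this exchange. The estimated 1.1-fold lower number from compound 2 to compound 4 (0.04 log units; within the scatter) is expected to stay within the scatter. For compound 4 the estimated value is 20000 nM with an expected range from 6000 nM to 70000 nM on this read-out.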

Compound 4, half-maximal inhibitory concentration: 90000 nM
Compound 4: middle estimate off by 4.5-fold (0.65 log units), on the low side; the measured number lies above the stated range.
By their numbers in this assay, from the lowest: compound 2; then compound 4; then compound 1; then compound 3.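

In this assay, among the compounds shown here, 3-chloroprop-1-yn-1-yl in place of 3-chloroprop-1-en-1-yl on a saturated chain carbon bound to an aromatic nitrogen gives a 4.1-fold higher number from compound 2 to compound 4 (0.61 log units; beyond the scatter) and so provides the first readable step. This position therefore responds to a double bond being exchanged for a triple bond, although the heavy-atom count stays the same. Nothing at hand accounts for this shift.

Going by these compounds, whether the step holds when bromine or an amine replaces the chlorine remains open, as does the outcome with a longer chain.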